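Shortening a chain on a shared core: compound 2 to compound 3

The compounds below may be only part of what the source reports. "The series", "measured", "known", "first", "only" and "open" are said of these compounds alone.

Compound 1, `CCCCC1(CCCNC)Cc2ccccc2N(c2ccc(C)cc2)C1=O`: in an assay on isolated protein for inhibition of sodium-dependent dopamine transporter (Homo sapiens) (on this read-out higher numbers stand for weaker inhibition and lower numbers for stronger inhibition), compound 1 gives > 200 nM, which is a limit of the assay, not a number.
Compound 2, `CCCC1(CCCNC)Cc2ccccc2N(c2ccccc2)C1=O`: in this assay compound 2 gives > 200 nM, again a limit of the assay.

Compound 2 therefore stands only at a limit; (the limit of > 200 nM in this assay, at which 2 of the 2 values shown sit). Compound 3, `CCC1(CCCNC)Cc2ccccc2N(c2ccccc2)C1=O`, differs from compound 2 by hydrogen in place of methyl on a saturated chain carbon, two bonds along the chain from a saturated ring carbon. Within the data shown here, no measured step on this core shows what such a change does. Compound 3 is expected to stay weak, with an estimated step from compound 2 to compound 3 of a step that the limit leaves unreadable from compound 2 to compound 3, most likely again reported only as a limit. The estimate for compound 3 is 600 nM, in the range 150 nM to 3000 nM.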

Compound 3, inhibition constant: > 200 nM
Compound 3 ended at the assay's limit; the forecaster's own chance of this, stated with the estimate: 70%; the middle value lies beyond the limit too.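

Compound 2 and compound 3 both give only a limit in this assay, not a number, and no step can be read between them. As far as these compounds go, what shortening the chain does to inhibition remains open.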